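Extending a Side Chain in an Inactive Pair

A few compounds are considered here, and "the series" means these few. Any claim that something is new, unique, unknown or untested is made for them only; others in the source may bear on it.

Of the compounds shown here, two built on the same core have been tested in a functional assay on the whole organism (strain Swiss) with Mus musculus as the target, in the maximal electroshock model, with a stated time of 0.5 h, at a dose of 100 mg/kg by the intraperitoneal route; a higher number here means a stronger effect of the compound at the dose given, a lower number a weaker effect. Compound 1, `CCC(C(=O)N1CCN(c2cccc(F)c2)CC1)N1C(=O)CCC1=O`, gives 0% in this assay. Compound 2, `CC(C(=O)N1CCN(c2ccccc2F)CC1)N1C(=O)CCC1=O`, gives 0% in this assay. Compound 2 thus stands level with compound 1 at the digits shown, and the two values lie within the scatter of each other, so neither can be called stronger or weaker than the other.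

The next compound, compound 3, `CCC(C(=O)N1CCN(c2ccccc2F)CC1)N1C(=O)CCC1=O`, has not yet been measured. It differs from compound 2 by one change: methyl in place of hydrogen on a saturated chain carbon, two bonds along the chain from an amide-type nitrogen in a ring and a carbonyl carbon. Going by the values given here, no step between measured compounds covers this change, so its size cannot be read from a pair already in hand. Both measured compounds show no effect at this dose, and compound 1, which also carries the ethyl chain, gives 0%. The expected step is therefore no change at the digits printed from compound 2 to compound 3 (within the scatter), that is, none beyond the scatter. Compound 3 is estimated to give 0%, with a range from 0% to 12%.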

Compound 3, a percentage reported as activity, at one dose (the size of the read-out at that dose, not a potency): 0%
Compound 3: the middle estimate sits on the measured number at the digits printed, and the stated range covers the measured number.
By their numbers in this assay, from the lowest: compounds 1, 2 and 3 (each within the scatter of the next).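

The step at this position reads no change at the digits printed from compound 2 to compound 3 (within the scatter) in this assay, so methyl in place of hydrogen on the saturated chain carbon, which turns a methyl side chain into an ethyl one, brings out no effect at the dose given. With the ethyl chain held in place, 2-fluorophenyl in place of 3-fluorophenyl on an amine nitrogen in a ring gives no change at the digits printed from compound 1 to compound 3 (within the scatter), which adds a second site where a single change leaves the read-out as it was. Going by these compounds alone, compound 3 gives 0%, so these steps show only that neither change is enough to produce a measurable effect in this test, not that the two positions have no influence on activity.

No other measurement bears on why the read-out stays the same across these compounds. Still open, going by these compounds, is whether a longer chain such as propyl at this position, or a chlorine atom in place of the fluorine on the phenyl ring, would give any effect at all under these conditions.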